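The compounds below may be only part of what the source reports. "The series", "measured", "known", "first", "only" and "open" are said of these compounds alone.

Of the compounds shown here, two sharing one core have been measured in a functional assay (spleen, spleen) for activation, with Mus musculus as the target; a higher number here means that more compound is needed for the effect, a lower number that less compound is needed. Compound 1 `CCCCc1nc(N)c2nc(O)n(Cc3ccccc3)c2n1` carries a butyl chain on the core and gives 0.03 uM. Compound 2 `CCNc1nc(N)c2nc(O)n(Cc3ccccc3)c2n1`, which carries an ethylamino group at the same place, gives 1 uM. Going by the values given here, of the two numbers so far, that of compound 2 is the higher one, and the single comparison available, a 33-fold higher number from compound 1 to compound 2 (1.52 log units; beyond the scatter), is large and lies well beyond the scatter of repeated measurements.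

Compound 3 `CCCCCSc1nc(N)c2nc(O)n(Cc3ccccc3)c2n1` has not yet been measured. It differs from compound 2 in one place: pentylsulfanyl in place of ethylamino on an aromatic carbon. The pentylsulfanyl group that enters brings no hydrogen-bond donor, and in that respect compound 3 is closer to compound 1 than to compound 2. Among the compounds with values here, the one step that bears on this change runs the other way: exchanging butyl for ethylamino raised the number sharply. Reversing that kind of exchange is therefore expected to lower the number again, and a step of about a 17-fold lower number from compound 2 to compound 3 (1.22 log units; beyond the scatter) is expected. For compound 3 in this assay the expected value is 0.06 uM, most likely between 0.01 uM and 0.4 uM.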

Compound 3, minimum effective concentration: 10 uM
Compound 3: middle estimate off by 170-fold (2.22 log units), on the low side; measured number outside the range, above it.
By their numbers in this assay, from the lowest: compound 1; then compound 2; then compound 3.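

In this assay, the change from ethylamino to pentylsulfanyl gives a 10-fold higher number from compound 2 to compound 3 (1.00 log units; beyond the scatter), so at this place on the shared core, removing the ethylamino group with its hydrogen-bond donor does not by itself bring the number down. Compared with the butyl group, the pentylsulfanyl group gives a 330-fold higher number from compound 1 to compound 3 (2.52 log units; beyond the scatter), which shows that a chain joined through sulfur cannot be treated as a stand-in for butyl joined directly through carbon, and that this position responds strongly to what is placed on it. Nothing measured here gives a reason for these steps.

The step from butyl to pentylsulfanyl alters both the linking atom and the length of the chain, so the compounds shown cannot tell which of the two accounts for the higher number. A plain pentyl chain would test the length with no sulfur present, while a butylsulfanyl group would test the sulfur with the chain length of compound 1 kept, and an ethylsulfanyl group would allow a direct comparison with the ethylamino group of compound 2.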